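Compound 2 to compound 3: changing the amide end

The source may report more compounds than this note shows. Statements on the series, on what has been measured and on what is new or still open speak of the compounds shown alone.

In a functional assay on MDA-MB-231 cells (Homo sapiens) for antiproliferative activity, read by MTT assay, with a stated time of 24 h (a lower number here means a stronger inhibitor, a higher number a weaker inhibitor), compound 1 `CCCCNC(=O)COc1ccc(C(=O)c2c(CCCC)oc3ccccc23)cc1` gives 34500 nM. Compound 2 `CCCCc1oc2ccccc2c1C(=O)c1ccc(OCC(=O)NCc2ccccc2)cc1` gives only a limit of the assay, > 50000 nM. Compound 3 `CCCCc1oc2ccccc2c1C(=O)c1ccc(OCCCC(=O)N2CCCCC2)cc1` has 2-((piperidin-1-yl)carbonyl)ethyl in place of benzylcarbamoyl on a saturated chain carbon bound to an oxygen on an aromatic ring. For the measured compounds named here, the only measured step, an at least 1.4-fold higher number from compound 1 to compound 2 (0.16 log units; that floor lies within the scatter), exchanges propyl for phenyl at the amide end and gives only a floor, so it bears loosely on this change. No step beyond the scatter is expected, and the estimated step is an at least 1.1-fold lower number from compound 2 to compound 3 (0.04 log units; that floor lies within the scatter). For compound 3 the expected value in this assay is 45000 nM, with an estimated range of 20000 nM to 90000 nM.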

Compound 3, half-maximal inhibitory concentration: 36000 nM
Compound 3: middle estimate off by 1.3-fold (0.10 log units), on the high side; low and high end bracket the measured number.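

At the place on a saturated chain carbon bound to an oxygen on an aromatic ring, 2-((piperidin-1-yl)carbonyl)ethyl replaces butylcarbamoyl, losing the amide hydrogen, and in this assay the result is a 1.0-fold higher number from compound 1 to compound 3 (0.02 log units; within the scatter). Against benzylcarbamoyl there is only a floor, an at least 1.3-fold lower number from compound 2 to compound 3 (0.14 log units; that floor lies within the scatter). Compound 2 stands at a limit, not a number: the limit of > 50000 nM in this assay, at which 1 of the 3 values shown sits.

Chain and amide end change together here, so neither can be credited separately. A carboxylic acid or a morpholine amide on either chain would test how much this end tolerates.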